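This account rests on a few compounds, and the source may have more. Where it says the series, first, only, none or still open, it means among the compounds named here.

Two compounds of the series carry numbers. In an assay on CHO cells for inhibition of sodium- and chloride-dependent glycine transporter 1 (Homo sapiens), read by scintillation counting (a higher number here means that more compound is needed for the effect, a lower number that less compound is needed), compound 1 `C[C@H](Oc1ccc(S(C)(=O)=O)cc1C(=O)N1Cc2ccc(N3CCCC3)cc2C1)C(F)(F)F` gives 180 nM, and compound 2 `C[C@H](Oc1ccc(S(C)(=O)=O)cc1C(=O)N1Cc2cc(C(F)(F)F)cnc2C1)C(F)(F)F` gives 50 nM. Compound 2 thus holds the lower of the two values, and compound 1 stands beyond the scatter above it. Compound 3 `CS(=O)(=O)c1ccc(-c2ccc(F)c(F)c2)c(C(=O)N2Cc3cc(C(F)(F)F)cnc3C2)c1` is not yet measured. It differs from compound 2 by 3,4-difluorophenyl in place of 1-(trifluoromethyl)ethoxy on an aromatic carbon. Among the measured compounds shown here, no pair of measured compounds shows this change, so its size is not known from the series. A moderate shift toward a higher number in this assay is expected, a 2.4-fold higher number from compound 2 to compound 3 (0.38 log units; beyond the scatter). For compound 3 a value of 120 nM is estimated, with a range of 40 nM to 400 nM.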

Compound 3, half-maximal effective concentration: 30 nM
Estimate against measurement, compound 3: 4.0-fold (0.60 log units) above, outside the stated range (below it).
By their numbers in this assay, from the lowest: compounds 3 and 2 (each within the scatter of the next); then compound 1.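

On the aromatic carbon para to a methylsulfonyl group, 3,4-difluorophenyl in place of 1-(trifluoromethyl)ethoxy gives a 1.7-fold lower number from compound 2 to compound 3 (0.22 log units; within the scatter) in this assay. In this pair, the position takes a six-membered aromatic ring of carbon only as readily as the open group, so neither the ether oxygen nor the defined stereocentre is needed for a value in this range. Still open, from the compounds shown here alone, is how an unsubstituted phenyl, a morpholine or a carboxylic acid on this carbon would read. No available evidence explains why the two groups read alike.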